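Adding phenyl to a compound at the assay limit

The source may report more compounds than this note shows. Statements on the series, on what has been measured and on what is new or still open speak of the compounds shown alone.

- compound 1 `COC(=O)CC/C(C)=C/Cc1c(OC)c(C)c2c(c1OCC#CCN1CCCc3ccccc31)C(=O)OC2`: > 50000 nM
- compound 2 `COC(=O)CC/C(C)=C/Cc1c(OC)c(C)c2c(c1OCC#CCN1CCC(C(=O)OC)CC1)C(=O)OC2`: > 50000 nM

In a functional assay on MDA-MB-231 cells (Homo sapiens) for inhibition, read by sulforhodamine B assay (a lower number here means a stronger inhibitor, a higher number a weaker inhibitor), compound 1 gives > 50000 nM, which is a limit of the assay and not a number. Compound 2 gives > 50000 nM, which is also a limit. The whole picture so far is the limit of > 50000 nM in this assay, at which 2 of the 2 values shown sit. Going by the values given here, the only measured step, a step that the two limits leave unreadable from compound 1 to compound 2, therefore has no size that could be carried over to another change.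

Compound 3 `COC(=O)CC/C(C)=C/Cc1c(OC)c(C)c2c(c1OCC#CCN1CCC(c3ccccc3)c3ccccc31)C(=O)OC2` carries phenyl in place of hydrogen on a saturated ring carbon. With no readable step to lean on, neither a size nor a direction can be argued for this assay, and a reading at the same limit is the most likely outcome. The expected a number no higher from compound 1 to compound 3 (the limit leaves the size open) is therefore no clear change. Compound 3 is estimated at 50000 nM, with an expected range of 15000 nM to 100000 nM.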

Compound 3, half-maximal inhibitory concentration: 28700 nM
Estimate against measurement, compound 3: 1.7-fold (0.24 log units) above; the measured number falls inside the stated range.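

In this assay, going by these compounds alone, compound 3 gives 28700 nM, the first value in this set that is a number and not a limit. Compound 1 stands at > 50000 nM, which is a limit of the assay. Phenyl in place of hydrogen on this saturated ring carbon gives an at least 1.7-fold lower number from compound 1 to compound 3 (0.24 log units; that floor lies within the scatter), so this position can carry a large ring and still give a readable value, but the true size of the step stays unknown.

Going by these compounds, how a methyl, a hydroxyl or an amine on this same ring carbon would read stays open, and so does the effect of a phenyl ring with its own substituent. Much of the set still gives no number to compare: the limit of > 50000 nM in this assay, at which 2 of the 3 values shown sit.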